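A few compounds are considered here, and "the series" means these few. Any claim that something is new, unique, unknown or untested is made for them only; others in the source may bear on it.

Compound 1 `O=C(O)/C(S)=C/c1ccccc1Cl` and compound 2 `O=C(O)/C(S)=C/c1ccccc1Br` share one core. In an assay on isolated protein for inhibition of Calpain-1 catalytic subunit (Sus scrofa), read by FRET (on this read-out higher numbers stand for weaker inhibition and lower numbers for stronger inhibition), compound 1 gives 11900 nM, and compound 2 gives 21000 nM. The change between them, (bromo in place of chloro on an aromatic carbon), made a step of a 1.8-fold higher number from compound 1 to compound 2 (0.25 log units; within the scatter). Compound 3 `O=C(O)/C(S)=C/c1c[nH]c2cccc(Cl)c12` is built on a different core; the difference between the two cores is not broken down here. In this assay compound 3 gives 20 nM, the lowest of the three measured numbers, beyond the scatter from both compound 1 and compound 2.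

Compound 4 `O=C(O)/C(S)=C/c1c[nH]c2cccc(Br)c12` is not yet measured. It differs from compound 3 by bromo in place of chloro on an aromatic carbon. Within the data shown here, this is the same kind of change as the one from compound 1 to compound 2, not the same: in compound 1 the aromatic carbon is ortho to a group of 6 heavy atoms, whereas in compound 3 it lies in a ring that is part of a fused or bridged system of two rings, ortho to a fused ring and meta to a fused ring.

For this assay the expected step is a 1.5-fold higher number from compound 3 to compound 4 (0.18 log units; within the scatter), set beside the earlier 1.8-fold higher number from compound 1 to compound 2 (0.25 log units; within the scatter), and it rests on that measured step a 1.8-fold higher number from compound 1 to compound 2 (0.25 log units; within the scatter) lying within the scatter. Compound 4 is therefore estimated at 30 nM in this assay, expected between 12 nM and 75 nM.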

Compound 4, half-maximal inhibitory concentration: 6 nM
For compound 4 the middle estimate is 5.0-fold (0.70 log units) above the measured one; measured number below the stated range.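

In this assay, bromo in place of chloro on an aromatic carbon does not carry over from the core of compound 1 to the core of compound 3, and the two steps differ: the same change on two cores in this assay, a 1.8-fold higher number (0.25 log units; within the scatter) from compound 1 to compound 2 and a 3.3-fold lower number (0.52 log units; beyond the scatter) from compound 3 to compound 4, 5.9-fold (0.77 log units) apart, beyond the scatter of two such steps. On the core of compound 3 the change gives a 3.3-fold lower number from compound 3 to compound 4 (0.52 log units; beyond the scatter), a modest step, so a step within the scatter on the core of compound 1 is a poor guide to the same change on the other core. The comparison rests on a single pair for each core, and it does not show which difference between the cores goes with the divergence, nor whether other changes would diverge in the same way.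

Still open, on these data alone, is whether the step on the core of compound 3 extends to fluoro or iodo on the same aromatic carbon, or to a non-halogen group such as methyl, methoxy or nitrile. Also open, as far as these compounds go, is how an amide or ester in place of the carboxylic acid would read on either core.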